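A few compounds are considered here, and "the series" means these few. Any claim that something is new, unique, unknown or untested is made for them only; others in the source may bear on it.

Measured compounds:
- compound 1, `O=C(Nc1cccc(-c2oc3cc(-c4ccc(F)cc4)ccc3c(=O)c2O)c1)c1ccc(Br)cc1F`: > 100000 nM
- compound 2, `COc1cc(OC)cc(C(=O)Nc2cccc(-c3oc4cc(-c5ccc(F)cc5)ccc4c(=O)c3O)c2)c1`: 23500 nM

Both compounds share one core and differ only in the aryl group on the carbonyl of the amide. In a functional assay on HepG2 cells (Homo sapiens) for antiproliferative activity, read by CCK-8 assay, with a stated time of 72 h (on this read-out lower numbers stand for stronger inhibition and higher numbers for weaker inhibition), compound 1 gives > 100000 nM, which is a limit of the assay rather than a number. In this assay, within the data shown here, compound 2 gives 23500 nM, the only plain number among the two, so compound 2 is the single fixed point here. The value of compound 1 is the limit described by the limit of > 100000 nM in this assay, at which 1 of the 2 values shown sits. The step of an at least 4.2-fold lower number from compound 1 to compound 2 (0.62 log units; beyond the scatter) shows that changing the aryl group on the carbonyl can move the read-out.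

Compound 3, `Cc1cc(C)cc(C(=O)Nc2cccc(-c3oc4cc(-c5ccc(F)cc5)ccc4c(=O)c3O)c2)c1`, continues on the same position: 3,5-dimethylphenyl in place of 3,5-dimethoxyphenyl on a carbonyl carbon. Among the measured compounds shown here, no measured step covers a methoxy-to-methyl exchange, so the expectation rests only on the observation that this position is sensitive. Compound 3 is expected to land close to compound 2, with a mild shift toward weaker inhibition, a 1.7-fold higher number from compound 2 to compound 3 (0.23 log units; within the scatter). The estimate for compound 3 is 40000 nM, within 12000 nM to 130000 nM.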

Compound 3, half-maximal inhibitory concentration: 13400 nM
Compound 3: middle estimate off by 3.0-fold (0.47 log units), on the high side; the measured number falls inside the stated range.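

Replacing 3,5-dimethoxyphenyl with 3,5-dimethylphenyl on a carbonyl carbon gives a 1.8-fold lower number from compound 2 to compound 3 (0.24 log units; within the scatter) in this assay, so the read-out of compound 3 stays level with that of compound 2 even though the 2 hydrogen-bond acceptors of the 3,5-dimethoxyphenyl group are gone. The separation from 4-bromo-2-fluorophenyl also appears with this second group, as an at least 7.4-fold lower number from compound 1 to compound 3 (0.87 log units; beyond the scatter), which shows that it does not depend on the methoxy groups and is shared by the 3,5-dimethoxyphenyl and 3,5-dimethylphenyl compounds. Compound 1 is a limit of the assay and not a number, so the true size of that separation remains unknown: the limit of > 100000 nM in this assay, at which 1 of the 3 values shown sits.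

The compounds shown leave open whether an amine, a carboxylic acid or a longer chain such as ethyl, carried in place of the two methyl groups, would move the read-out beyond the scatter around compound 2 and compound 3. They also do not tell whether the bromine or the fluorine of 4-bromo-2-fluorophenyl, taken alone, accounts for the limit seen with compound 1.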